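The source may hold more compounds than are shown below. What is called first, only, known or untested is meant among the compounds shown, and "the series" means these compounds.

Measured compounds:
- Compound 1 `CCC(C)(C)Cc1c[nH]c(CCc2ccc(-c3cccnc3)cc2)n1` gives 131 nM in a functional assay on HEK293 cells for agonist activity at Bombesin receptor subtype-3 (Homo sapiens), read by luminescence and calcium flux, with a stated time of 10 min; a higher number here means that more compound is needed for the effect, a lower number that less compound is needed.
- Compound 2 `CCC(C)(C)Cc1c[nH]c(CCc2ccc(-c3ccc(F)cn3)cc2)n1` gives 66 nM in this assay.
- Compound 3 `CCC(C)(C)Cc1c[nH]c(CCc2ccc(-c3ccns3)cc2)n1` gives 63 nM in this assay.

Of these three, compound 1 has the highest number, that is, it needs the most compound for the effect. The gap to compound 2 is a 2.0-fold lower number from compound 1 to compound 2 (0.30 log units; within the scatter), and the gap to compound 3 is a 2.1-fold lower number from compound 1 to compound 3 (0.32 log units; beyond the scatter), so compound 1 sits at the top of a narrow spread rather than far from the rest. Compounds 2 and 3 sit together, with a 1.0-fold lower number from compound 2 to compound 3 (0.02 log units; within the scatter).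

Compound 4 `CCC(C)(C)Cc1c[nH]c(CCc2ccc(-c3cccc(C)n3)cc2)n1` is not yet measured. Compared with compound 1 it carries one change: 6-methylpyridin-2-yl in place of pyridin-3-yl on an aromatic carbon. Within the data shown here, the steps that bear on this are the two replacements of the same pyridin-3-yl group already seen, from compound 1 to compound 2 and from compound 1 to compound 3. Both moved the number down by about the same small amount, one within the scatter, one just beyond it. Neither tells anything about a methyl on the entering ring, so the safest expectation is a step no larger than those, in the same downward direction or none beyond the scatter.

For compound 4, the estimate is 90 nM, with a likely range from 30 nM to 300 nM. That corresponds to an expected step of a 1.5-fold lower number from compound 1 to compound 4 (0.16 log units; within the scatter).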

Compound 4, half-maximal effective concentration: 105 nM
Compound 4: middle estimate off by 1.2-fold (0.07 log units), on the low side; measured number inside the range.
By their numbers in this assay, from the lowest: compounds 3, 2, 4 and 1 (each within the scatter of the next, the first and the last beyond it).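

Replacing pyridin-3-yl with 6-methylpyridin-2-yl at this place on the carbon-only aromatic ring gives a 1.2-fold lower number from compound 1 to compound 4 (0.10 log units; within the scatter) in this assay, so a pyridine carrying a methyl is accepted here with no change that can be told from the scatter. Compound 4 also cannot be separated from the two other replacements, as shown by a 1.7-fold higher number from compound 3 to compound 4 (0.22 log units; within the scatter) and by a 1.6-fold higher number from compound 2 to compound 4 (0.20 log units; within the scatter), which places it within the scatter of all three earlier compounds, even though the step from compound 1 to compound 3 lies just beyond it. No data are available to explain why these different aromatic groups give such similar numbers.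

The compounds shown do not separate the effect of the methyl from that of the ring's point of attachment, a question that plain pyridin-2-yl or 6-methylpyridin-3-yl would address directly. On these data alone, it also remains open how this place would respond to a group of a different kind, such as a carboxylic acid, a piperidine, or a short amine chain in place of the aromatic ring.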